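Adding chloro to the phenyl of compound 2

The source may hold more compounds than are shown below. What is called first, only, known or untested is meant among the compounds shown, and "the series" means these compounds.

In a toxicity assay on THP-1 cells (Homo sapiens) for inhibition (on this read-out higher numbers stand for lower toxicity in this test and lower numbers for higher toxicity in this test), compound 2 (`Cn1c(-c2ccccc2)cnc1NC(=O)c1ncc[nH]1`) gives > 100000 nM as a limit of the assay, so its standing is known only as a limit. Compound 1 (`Cn1c(-c2ccccc2Cl)cnc1NC(=O)c1ncc[nH]1`), which also carries a chloro, gives > 50000 nM as a limit too. Going by the values given here, the one measured step is a step that the two limits leave unreadable from compound 1 to compound 2 and offers no size to carry over. Compound 3 (`Cn1c(-c2cccc(Cl)c2)cnc1NC(=O)c1ncc[nH]1`) changes phenyl to 3-chlorophenyl, with chloro in place of hydrogen on an aromatic carbon. Only a small downward move or none is expected in this assay and another limit is likely. The expected step is an at least 1.6-fold lower number from compound 2 to compound 3 (0.22 log units; that floor lies within the scatter) as an estimate. Compound 3 is estimated at 60000 nM with a range from 25000 nM to 120000 nM as expected bounds.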

Compound 3, half-maximal cytotoxic concentration: 55000 nM
Estimate against measurement, compound 3: 1.1-fold (0.04 log units) above; low and high end bracket the measured number.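

In this assay, going by these compounds alone, compound 3 gives the first true number rather than a limit, and adding chloro on this aromatic carbon reads as an at least 1.8-fold lower number from compound 2 to compound 3 (0.25 log units; that floor lies within the scatter). Going by these compounds, the full size of that step stays open because compound 2 stands only at a limit: the limit of > 100000 nM in this assay, at which 1 of the 3 values shown sits. The step between compound 1 and compound 3 cannot be read, so the two chloro placements cannot be ranked. Still open, on these data alone, is whether an amine, a carboxylic acid or a longer chain in place of chloro would move the number beyond the scatter.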